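Cyclohexyl for phenyl on the urea nitrogen of compound 2

The source may hold more compounds than are shown below. What is called first, only, known or untested is meant among the compounds shown, and "the series" means these compounds.

Compound 1 `CCCNC(=O)/N=C(\N)NCCCc1sc(N)nc1C`: 170 nM
Compound 2 `Cc1nc(N)sc1CCCN/C(N)=N/C(=O)Nc1ccccc1`: 3390 nM

In a functional assay on HEK293T cells for agonist activity at histamine H2 receptor (Homo sapiens), read by beta-arrestin recruitment (on this read-out lower numbers stand for an effect already at smaller amounts and higher numbers for an effect only at larger amounts of compound), compound 2 gives the higher of the two numbers; its neighbour compound 1 is reached by a step that reads a 20-fold higher number from compound 1 to compound 2 (1.30 log units; beyond the scatter) in the reverse direction. Compound 3 `Cc1nc(N)sc1CCCN/C(N)=N/C(=O)NC1CCCCC1` differs from compound 2 in one place: cyclohexyl in place of phenyl on an amide-type nitrogen. Among the compounds with values here, the only step that bears on this is the exchange of propyl for phenyl, which was large, and cyclohexyl is again a non-aromatic group. The expected step in this assay is therefore a 7.5-fold lower number from compound 2 to compound 3 (0.88 log units; beyond the scatter), downward. Compound 3 is estimated at 450 nM, within 120 nM to 1700 nM.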

Compound 3, half-maximal effective concentration: 389 nM
For compound 3 the middle estimate is 1.2-fold (0.06 log units) above the measured one, and the stated range covers the measured number.
By their numbers in this assay, from the lowest: compound 1; then compound 3; then compound 2.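

In this assay, the step of an 8.7-fold lower number from compound 2 to compound 3 (0.94 log units; beyond the scatter) shows that the high number of compound 2 does not come with a six-membered carbon ring as such on the amide-type nitrogen, since the same count of carbons without aromaticity gives much of the loss back. The step of a 2.3-fold higher number from compound 1 to compound 3 (0.36 log units; beyond the scatter) still lies beyond the scatter, so cyclohexyl does not fully match propyl at this position. Nothing shown explains either step.
From the compounds shown here alone, whether cyclopentyl, isopropyl or a longer chain such as hexyl would come closer to propyl stays open. So does whether benzyl would behave like phenyl or like cyclohexyl.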